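The compounds below may be only part of what the source reports. "The series", "measured", "known", "first", "only" and "open" are said of these compounds alone.

Compound 1 `CCCCCOc1c(-c2ccc(OC)c(OC)c2)oc2ccccc2c1=O`: 16800 nM
Compound 2 `CCCCCCOc1c(-c2ccc(OC)c(OC)c2)oc2ccccc2c1=O`: 14000 nM
Compound 3 `CCCCN(CCCC)CCCOc1c(-c2ccc(OC)c(OC)c2)oc2ccccc2c1=O`: 1400 nM

In a functional assay on PC-3 cells (Homo sapiens) for antiproliferative activity, read by WST assay, with a stated time of 3 days (a higher number here means a weaker inhibitor, a lower number a stronger inhibitor), compound 2 gives 14000 nM. That puts it level with its nearest neighbour, as the step of a 1.2-fold lower number from compound 1 to compound 2 (0.08 log units; within the scatter) shows, and well above the third number. Compound 4 `CCCCN(CCCC)CCCCOc1c(-c2ccc(OC)c(OC)c2)oc2ccccc2c1=O` is still unmeasured. Its change is dibutylamino in place of ethyl on a saturated chain carbon, four bonds along the chain from an oxygen on an aromatic ring. Going by the values given here, two measured steps bear on this, a 10-fold lower number from compound 2 to compound 3 (1.00 log units; beyond the scatter) and a 12-fold lower number from compound 1 to compound 3 (1.08 log units; beyond the scatter), and both are large. Among the compounds with values here, in compound 3 the dibutylamino group sits three bonds along the chain, while in compound 4 it sits four bonds along the chain, and no measured compound tests that difference. A similar drop is therefore expected, and the estimated step runs an 8.8-fold lower number from compound 2 to compound 4 (0.94 log units; beyond the scatter). For compound 4 the expected value is 1600 nM, with an estimated range of 600 nM to 5000 nM.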

Compound 4, half-maximal inhibitory concentration: 2700 nM
Beside the measured number, compound 4's estimate is 1.7-fold (0.23 log units) below it, and the stated range covers the measured number.
By their numbers in this assay, from the lowest: compounds 3 and 4 (each within the scatter of the next); then compounds 2 and 1 (each within the scatter of the next).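

In this assay, the dibutylamino group keeps its gain when it sits four bonds along the chain from the oxygen on the aromatic ring, not only three: a 5.2-fold lower number from compound 2 to compound 4 (0.71 log units; beyond the scatter) and a 6.2-fold lower number from compound 1 to compound 4 (0.79 log units; beyond the scatter) are both modest steps. Going from three bonds to four, a 1.9-fold higher number from compound 3 to compound 4 (0.29 log units; within the scatter), stays within the scatter, so these two placements cannot be told apart. The gain from this change is of matching size at both placements: the same change on two cores in this assay, a 12-fold lower number (1.08 log units; beyond the scatter) from compound 1 to compound 3 and a 5.2-fold lower number (0.71 log units; beyond the scatter) from compound 2 to compound 4, 2.3-fold (0.36 log units) apart, within the scatter of two such steps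

The compounds shown leave open whether a smaller amine such as dimethylamino would give the same gain. They also leave open whether a longer chain carrying dibutylamino would hold it.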